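A methyl in place of fluoro in a cytotoxicity series

This account rests on a few compounds, and the source may have more. Where it says the series, first, only, none or still open, it means among the compounds named here.

Compound 1 (`Cc1c(F)c(N2CCC(N)C2)c(F)c2c1c(=O)c(C(=O)O)cn2C1CC1`): 11 ug/mL 
Compound 2 (`CCNCC1CCN(c2c(F)c(F)c3c(=O)c(C(=O)O)cn(C4CC4)c3c2F)C1`): 46 ug/mL 

Both compounds were tested in a functional assay on V79 cells (Cricetulus griseus) for cytotoxicity, read by colony formation; a lower number here means a stronger inhibitor, a higher number a weaker inhibitor. Compound 2 has the higher of the two numbers, so it is the weaker inhibitor here. At 46 ug/mL compound 2 lies above compound 1, and the gap between them is beyond the usual scatter. Among the measured compounds shown here, no measured pair yet isolates a single structural change, so the size of the next step can only be judged loosely.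

Compound 3 (`CCNCC1CCN(c2c(F)c(C)c3c(=O)c(C(=O)O)cn(C4CC4)c3c2F)C1`) is the next to be measured. It differs from compound 2 by one substitution, methyl in place of fluoro on an aromatic carbon. Compound 1 also carries a methyl on the core and gives 11 ug/mL in this assay, but it differs from compound 2 elsewhere as well, so it offers only a weak guide. A modest move towards a lower number is therefore expected, though a result within the scatter would not surprise. The expected change is a 2.1-fold lower number from compound 2 to compound 3 (0.32 log units; beyond the scatter) in this assay. For compound 3 the estimated value is 22 ug/mL, with an expected range from 7 ug/mL to 65 ug/mL.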

Compound 3, half-maximal inhibitory concentration: 9 ug/mL
Compound 3: the middle estimate sits 2.4-fold (0.39 log units) above what was measured; the range from low to high includes it.
By their numbers in this assay, from the lowest: compounds 3 and 1 (each within the scatter of the next); then compound 2.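

In this assay, among the compounds shown here, methyl in place of fluoro on this aromatic carbon, para to a fluoro group, gives the first step that isolates a single change: a 5.1-fold lower number from compound 2 to compound 3 (0.71 log units; beyond the scatter). This shows that the number responds strongly to this one-atom exchange at this position when the 3-((ethylamino)methyl)pyrrolidin-1-yl group is present, whereas the earlier pair differed in more than one place and could not show this. With the methyl on the core, (ethylamino)methyl in place of amino on the saturated ring carbon gives a 1.2-fold lower number from compound 1 to compound 3 (0.09 log units; within the scatter), and nothing shown accounts for either result.

From the compounds shown here alone, whether a chloro, a methoxy or an ethyl group on this aromatic carbon would give a number close to that of compound 3 remains open. Going by these compounds, it is also open whether the exchange of fluoro for methyl would give a step of the same size with an amino group on the saturated ring carbon, or with a different amine in that place.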